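This account rests on a few compounds, and the source may have more. Where it says the series, first, only, none or still open, it means among the compounds named here.

Compound 1 `CCCc1ccc(C(=O)Nc2cc3nc(C4CCCCC4)[nH]c3cc2N(C)C)cc1`: in an ADME assay on Vero cells (Chlorocebus sabaeus) for cytotoxicity, read by resazurin assay, with a stated time of 3 days (on this read-out higher numbers stand for weaker inhibition and lower numbers for stronger inhibition), compound 1 gives the limit > 100 ug/mL.
Compound 2 `CCCc1ccc(C(=O)Nc2cc3nc(C4CCCCC4)[nH]c3cc2N(CC)CC)cc1`: in this assay compound 2 gives "not determined" (no result reported).
Compound 3 `CN(C)c1cc2[nH]c(C3CCCCC3)nc2cc1NC(=O)OCC(F)(F)F`: in this assay compound 3 gives the limit > 100 ug/mL.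

Compound 2 thus stands without a number in this assay; its place among the others cannot be read. Compound 4 `CCN(CC)c1cc2[nH]c(C3CCCCC3)nc2cc1NC(=O)c1cccc(Br)c1` is not yet measured. It differs from compound 2 by 3-bromophenyl in place of 4-propylphenyl on a carbonyl carbon.

Going by the values given here, the only measured single step in this assay, a step that the two limits leave unreadable from compound 1 to compound 3, involves a change at the same carbonyl carbon and is unreadable, since (the limit of > 100 ug/mL in this assay, at which 2 of the 3 values shown sit). No readable step therefore bears on the change to compound 4, and none beyond the scatter is expected; a value at or near the limit is the most likely outcome.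

Compound 4 is accordingly expected at 100 ug/mL in this assay, within 40 ug/mL to 250 ug/mL.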

Compound 4, half-maximal inhibitory concentration: > 100 ug/mL
Compound 4 gave a limit, no number (the forecaster's own chance of this, stated with the estimate: 70%); the middle value sits exactly at the limit.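

No step from compound 2 to compound 4 can be read, since compound 2 carries no number and compound 4 gives only a limit: the limit of > 100 ug/mL in this assay, at which 3 of the 4 values shown sit.

The compounds shown leave open how 3-bromophenyl and 4-propylphenyl on the carbonyl carbon compare in this assay.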